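This account rests on a few compounds, and the source may have more. Where it says the series, first, only, none or still open, it means among the compounds named here.

Measured compounds:
compound 1, `Cc1cc(O)cc(-c2nn(CC#N)cc2-c2ccnc(-c3ccc(Oc4ccccc4)cc3)c2)c1`, with 35% in a functional assay on NCI-H322M cells (Homo sapiens) for cytotoxicity, read by sulforhodamine B assay, with a stated time of 48 h, tested at 1 uM; on this read-out higher numbers stand for a weaker effect at the one concentration tested and lower numbers for a stronger effect
compound 2, `COc1cc(C)cc(-c2nn(CC#N)cc2-c2ccnc(-c3ccc(N(C)C)cc3)c2)c1`, with 52% in this assay

Compound 2 stands highest of the two numbers in this assay; its nearest neighbour, compound 1, gives 35%, a gap beyond the usual scatter. Going by the values given here, no pair of these two differs in one place only, so no single step has yet been measured.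

Compound 3, `Cc1cc(O)cc(-c2nn(CC#N)cc2-c2ccnc(-c3ccc(N(C)C)cc3)c2)c1`, is still to be measured in this assay. It follows from compound 2 by one change: hydrogen in place of methyl on an oxygen on an aromatic ring. Compound 3 also shares the 3-hydroxy-5-methylphenyl part with compound 1, but the two differ elsewhere as well, so the values of compound 1 and compound 2 only bracket the plausible range and do not fix the step.

Among the compounds with values here, with no measured step for this change, the expected move from compound 2 to compound 3 in this assay is a number 7 percentage points lower from compound 2 to compound 3 (within the scatter), small and probably within the scatter, leaning lower. Compound 3 is estimated at 45%, with a range from 25% to 65%.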

Compound 3, a percentage reported as activity, at one concentration (the size of the read-out at that concentration, not a potency): 38%
For compound 3 the middle estimate is 7 percentage points above the measured one; the measured number falls inside the stated range.
By their numbers in this assay, from the lowest: compounds 1 and 3 (each within the scatter of the next); then compound 2.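

In this assay, going by these compounds alone, the hydroxy compound gives the first measured single change, a number 14 percentage points lower from compound 2 to compound 3 (beyond the scatter) and, with lower numbers standing for a stronger effect, methoxy to hydroxy goes with a stronger effect at the one concentration tested while the dimethylamino group stays in place. With the 3-hydroxy-5-methylphenyl part held constant, dimethylamino in place of phenoxy gives a number 3 percentage points higher from compound 1 to compound 3 (within the scatter) so this exchange of two quite different groups on an aromatic carbon leaves the read-out unresolved in this series. No available measurement bears on either step or accounts for the effect of the hydroxy group.

Whether hydrogen in place of methyl on that oxygen gives a similar step in the phenoxy compound remains open, since this change has been read only with dimethylamino in the compounds shown. Also open, from the compounds shown here alone, is how an ethyl group on that oxygen, or an amino group in place of the hydroxy, would read in this assay and whether either would separate from the hydroxy compound by more than the usual scatter.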